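This account rests on a few compounds, and the source may have more. Where it says the series, first, only, none or still open, it means among the compounds named here.

In an assay on isolated protein for inhibition of tyrosine-protein kinase receptor UFO (Homo sapiens), with a stated time of 1.5 h (a higher number here means a weaker inhibitor, a lower number a stronger inhibitor), compound 1 `Cn1cc(-c2n[nH]c3ccc(-c4ccccc4)cc23)cn1` gives 620 nM, and compound 2 `Clc1cc2[nH]nc(-c3cnn(-c4ccccc4)c3)c2cc1N[C@@H]1CCNC1` gives 1700 nM. Compound 3 `Nc1ccc2c(Br)n[nH]c2c1` stands apart from these two: in this assay it returns only a limit, > 770000 nM, and not a number. That is where compound 3 stands among the values shown, at the limit of > 770000 nM in this assay, at which 1 of the 3 values shown sits, while the other two compounds each carry a measured number.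

Compound 4 `O=C(O)c1ccc2c(Br)n[nH]c2c1` is the compound that remains to be measured. It differs from compound 3 by carboxy in place of amino on an aromatic carbon. Among the compounds with values here, no pair of measured compounds shows this particular change, so there is no measured step to lean on; the only point of reference is compound 3, and for that compound the assay gives a limit rather than a value. With so little to go on, the expected step in this assay is none beyond the scatter, and the more likely outcome is that compound 4 also returns a limit rather than a number. The estimate for compound 4 in this assay is 800000 nM, in the range 150000 nM to 4000000 nM. The step this estimate implies is a step that the limit leaves unreadable from compound 3 to compound 4, expected to stay within scatter.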

Compound 4, half-maximal inhibitory concentration: > 770000 nM
Compound 4 ended at the assay's limit; the forecaster's own chance of this, stated with the estimate: 80%; the middle value does not contradict the limit.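

Within the data shown here, compound 3 and compound 4 both return only a limit in this assay, not a number, so no step between them can be read: the limit of > 770000 nM in this assay, at which 2 of the 4 values shown sit. The compounds shown leave open whether carboxy in place of amino on an aromatic carbon changes inhibition in this assay at all.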